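The compounds below may be only part of what the source reports. "The series", "measured", "known", "first", "only" and "open" are said of these compounds alone.

Working notes on the series.

Of the compounds shown here, three of one core have been measured in a functional assay on the whole organism for inhibition, with Rattus norvegicus as the target, in the maximal electroshock model, at a dose of 25 mg/kg by the intraperitoneal route; on this read-out higher numbers stand for more inhibition at the one dose given (going by the name of the read-out) and lower numbers for less inhibition. Compound 1 `c1ccc(Cn2cnc3c(N4CCC4)ncnc32)cc1` gives 17%. Compound 2 `CN(C=O)c1ncnc2c1ncn2Cc1ccccc1` gives 0%. Compound 3 `Cc1ccc(Cn2cnc3c(N(C)C)ncnc32)cc1` gives 0%. Among the compounds with values here, the single one-place step in the measured set is a number 17 percentage points lower from compound 1 to compound 2 (beyond the scatter), which concerns the amine on the core rather than the phenyl ring. Compound 3 stands level with compound 2 at the digits given, the two together being the lowest of the three numbers, while compound 1 sits a number higher than compound 3 by an amount beyond the scatter.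

Compound 4 `CN(C)c1ncnc2c1ncn2Cc1ccc([N+](=O)[O-])cc1` differs from compound 3 by nitro in place of methyl on an aromatic carbon, on an aromatic carbon of a six-membered aromatic ring of carbon only. Within the data shown here, no measured step touches that ring, so nothing in the set bears directly on this change; the only measured step, from compound 1 to compound 2, sits elsewhere. The expectation for compound 4 is therefore a number 5 percentage points higher from compound 3 to compound 4 (within the scatter), a step not beyond the scatter. Compound 4 is estimated at 5%, in the range 0% to 25%.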

Compound 4, a percentage reported as inhibition, in the whole organism at one dose (the size of the read-out at that dose, not a potency): 0%
For compound 4 the middle estimate is 5 percentage points above the measured one; measured number inside the range.
By their numbers in this assay, from the lowest: compounds 2, 3 and 4 (each within the scatter of the next); then compound 1.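

In this assay, the first step read on the six-membered aromatic ring of carbon only gives no change at the digits printed from compound 3 to compound 4 (within the scatter), so nitro in place of methyl, para to a large group, leaves the printed number unchanged while the core carries dimethylamino. Within the data shown here, both compounds of this step sit at the low end of the series, so it shows only that this exchange does not lift the number here, not that the ring position is without influence. Nothing on hand accounts for this result.

Open, going by these compounds, is whether the same exchange would read differently with the azetidin-1-yl group of compound 1 on the core. Also open, on these data alone, is whether an amine, a carboxylic acid or a longer chain on that ring carbon would move the number at all.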